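Trimming the tert-butyl group: compound 3 to compound 4

A few compounds are considered here, and "the series" means these few. Any claim that something is new, unique, unknown or untested is made for them only; others in the source may bear on it.

The three measured compounds share one core and differ in the group on the aromatic carbon of the five-membered ring. Compound 1 `CCCCc1ccc(-c2cc(-c3cn([C@H]4C[C@H](OC(C)=O)[C@@H](COC(C)=O)O4)c(=O)[nH]c3=O)on2)cc1` carries a 4-butylphenyl group and in a functional assay on NCI-H23 cells (Homo sapiens) for cytotoxicity, read by sulforhodamine B assay, tested at 10 uM (a lower number here means less inhibition, a higher number more inhibition at the concentration tested (going by the name of the read-out)), gives 97.4%. Compound 2 `CCCCCc1cc(-c2cn([C@H]3C[C@H](OC(C)=O)[C@@H](COC(C)=O)O3)c(=O)[nH]c2=O)on1` carries a pentyl group and in this assay gives 88.9%. Compound 3 `CC(=O)OC[C@H]1O[C@@H](n2cc(-c3cc(-c4ccc(C(C)(C)C)cc4)no3)c(=O)[nH]c2=O)C[C@@H]1OC(C)=O` carries a 4-(tert-butyl)phenyl group and in this assay gives 112%, the highest of the three numbers; it lies a number 14.6 percentage points higher from compound 1 to compound 3 (beyond the scatter) and a number 23.1 percentage points higher from compound 2 to compound 3 (beyond the scatter), both beyond the scatter.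

Compound 4 `CC(=O)OC[C@H]1O[C@@H](n2cc(-c3cc(-c4ccc(C(C)C)cc4)no3)c(=O)[nH]c2=O)C[C@@H]1OC(C)=O` is the next step from compound 3: hydrogen in place of methyl on a saturated chain carbon bound to an aromatic carbon and two saturated chain carbons. For the measured compounds named here, the only measured step that touches the same group is the one from compound 1 to compound 3, where butyl became tert-butyl with a modest rise; no step from a branched group to a smaller branched group has been measured. Compound 3 already sits near the upper limit of this read-out, so compound 4 is expected to stay close to it, with a step of a number 8 percentage points lower from compound 3 to compound 4 (within the scatter) at most. Compound 4 is estimated at 104%, between 90% and 117%.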

Compound 4, a percentage reported as inhibition, at one concentration (the size of the read-out at that concentration, not a potency): 108%
For compound 4 the middle estimate is 4 percentage points below the measured one; the range from low to high includes it.
By their numbers in this assay, from the lowest: compounds 2 and 1 (each within the scatter of the next); then compounds 4 and 3 (each within the scatter of the next).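

Taking one methyl off the tert-butyl group to leave isopropyl is the first change measured at this branched carbon itself, and in this assay it amounts to a number 4 percentage points lower from compound 3 to compound 4 (within the scatter), so this read-out does not separate the two branched groups. The isopropyl compound still stands clear of the two straight-chain compounds, with a number 10.6 percentage points higher from compound 1 to compound 4 (beyond the scatter) and a number 19.1 percentage points higher from compound 2 to compound 4 (beyond the scatter), so the gaps seen with tert-butyl also appear with the smaller branch. Nothing at hand explains why these two branched groups read alike.

As far as these compounds go, it remains open whether an ethyl group or a cyclopropyl group in place of isopropyl would keep the number at this level. From the compounds shown here alone, it is also open whether the same order would hold with free hydroxyl groups in place of the two acetate esters.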